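The source may report more compounds than this note shows. Statements on the series, on what has been measured and on what is new or still open speak of the compounds shown alone.

Measured so far in a functional assay on DU-145 cells (Homo sapiens) for cytotoxicity, read by MTT assay, with a stated time of 72 h; on this read-out lower numbers stand for an effect already at smaller amounts and higher numbers for an effect only at larger amounts of compound:
- compound 1 `CCc1cccc2c(OC)c(-c3occ(C)c3C(=S)OC)ccc12`: compound 1 gives 5.7 ug/mL.
- compound 2 `CCOCc1c(C)coc1-c1ccc2c(CC)cccc2c1OC`: compound 2 gives only a limit, > 10 ug/mL.

Compound 2 thus stands at the limit of > 10 ug/mL in this assay, at which 1 of the 2 values shown sits, and no number is known for it. Compound 3 `CCc1cccc2c(OC)c(-c3occ(C)c3CBr)ccc12` differs from compound 2 by bromo in place of ethoxy on a saturated chain carbon bound to an aromatic carbon. Among the compounds with values here, the one measured step, an at least 1.7-fold higher number from compound 1 to compound 2 (0.24 log units; that floor lies within the scatter), exchanges a different group and ends at a limit, so it gives no direct guide to the bromo for ethoxy exchange. In this assay no step beyond the scatter is expected for compound 3. The estimate for compound 3 is 9 ug/mL (2.5 ug/mL to 30 ug/mL), an expected at least 1.1-fold lower number from compound 2 to compound 3 (0.04 log units; that floor lies within the scatter).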

Compound 3, concentration for half-maximal effect: > 10 ug/mL
Compound 3 ended at the assay's limit; the forecaster's own chance of this, stated with the estimate: 45%; middle value at least 1.1-fold (0.04 log units) from the limit.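

Compound 3 carries bromomethyl in place of the ethoxymethyl of compound 2. In this assay compound 3 gives only a limit, > 10 ug/mL. The step between compound 2 and compound 3 cannot be read. Relative to the group on compound 1, the second replacement gives an at least 1.7-fold higher number from compound 1 to compound 3 (0.24 log units; that floor lies within the scatter), so neither ethoxymethyl nor bromomethyl yields a number at this position. The limit now covers most of the values shown: the limit of > 10 ug/mL in this assay, at which 2 of the 3 values shown sit.

On these data alone, how far compound 2 and compound 3 lie past their limits remains open. So does the effect of an amine or a carboxylic acid at this position.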